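The source may report more compounds than this note shows. Statements on the series, on what has been measured and on what is new or still open speak of the compounds shown alone.

Measured compounds:
compound 1, `c1ccc2c(-c3cn4ccnc4c(-c4ccc5ncn(C6CCCCC6)c5c4)n3)cccc2c1`: 19.3%
compound 2, `Fc1ccc(-c2cn3ccnc3c(-c3ccc4ncn(C5CCCCC5)c4c3)n2)cc1`: 15.5%

In a functional assay on NCI-H522 cells (Homo sapiens) for inhibition, read by sulforhodamine B assay, with a stated time of 48 h, tested at 10 uM (a higher number here means more inhibition at the concentration tested (going by the name of the read-out), a lower number less inhibition), compound 1 gives 19.3% and compound 2 gives 15.5%. Among the compounds with values here, the only measured step, a number 3.8 percentage points lower from compound 1 to compound 2 (within the scatter), is within the scatter, so the two values cannot be set in any order. Compound 3, `CC(=O)c1ccc(-c2cn3ccnc3c(-c3ccc4ncn(C5CCCCC5)c4c3)n2)cc1`, has not yet been measured. It differs from compound 2 in one place: acetyl in place of fluoro on an aromatic carbon. Within the data shown here, the one measured step also exchanged the group on this aromatic carbon of the shared core, and it was small. With a single step of that size and nothing else to go on, no movement beyond the scatter is expected in this assay for compound 3. The estimated step is a number 1.5 percentage points higher from compound 2 to compound 3 (within the scatter). For compound 3 the estimate is 17%, with a range from 4% to 32%.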

Compound 3, a percentage reported as inhibition, at one concentration (the size of the read-out at that concentration, not a potency): 10.4%
Compound 3: the middle estimate sits 6.6 percentage points above what was measured; measured number inside the range.
By their numbers in this assay, from the lowest: compounds 3, 2 and 1 (each within the scatter of the next).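

With acetyl in place of fluoro, this assay shows a number 5.1 percentage points lower from compound 2 to compound 3 (within the scatter) and, with 4-acetylphenyl in place of naphthalen-1-yl, a number 8.9 percentage points lower from compound 1 to compound 3 (within the scatter) so that none of the three groups on this aromatic carbon can be set apart from the others. The earlier pair held no group with a hydrogen-bond acceptor or a double bond outside aromatic rings at this place, and acetyl, which brings one of each, still gives no step beyond the scatter. No measurement at hand bears on why these numbers stay so close.

On these data alone, it remains open whether an amine or a carboxylic acid in place of the acetyl would give a step beyond the scatter. As far as these compounds go, a longer chain on the same carbon is equally open.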